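The compounds below may be only part of what the source reports. "The series", "measured", "known", "first", "only" and "open" are said of these compounds alone.

In a functional assay on MT2 cells (Homo sapiens) for antiproliferative activity, read by MTT assay, with a stated time of 72 h (a higher number here means a weaker inhibitor of growth, a lower number a stronger inhibitor of growth), compound 1 (`O=C(COc1ccc2oc(-c3ccccc3)cc(=O)c2c1)Nc1ccc(-c2ccccc2)cc1`) gives > 10000 nM, which is a limit of the assay and not a number. Compound 2 (`O=C(COc1ccc2c(=O)cc(-c3ccccc3)oc2c1)Nc1ccccc1`) gives > 10000 nM, and this too is only a limit. Neither compound therefore has a numerical value, and the measured set offers only (the limit of > 10000 nM in this assay, at which 2 of the 2 values shown sit). Compound 3 (`COc1ccc(NC(=O)COc2ccc3c(=O)cc(-c4ccccc4)oc3c2)cc1`) differs from compound 2 by methoxy in place of hydrogen on an aromatic carbon of a six-membered aromatic ring of carbon only, para to a large group, which turns phenyl into 4-methoxyphenyl. Among the measured compounds shown here, no measured step shows what this change does in this assay, so no direction can be argued from the data. The expected size of a number no higher from compound 2 to compound 3 (the limit leaves the size open) is none beyond the scatter. Compound 3 is estimated at 10000 nM, with an expected range from 4000 nM to 25000 nM.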

Compound 3, concentration for 50% growth inhibition: 6700 nM
Estimate against measurement, compound 3: 1.5-fold (0.17 log units) above; measured number inside the range.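

In this assay, among the compounds shown here, compound 3 gives 6700 nM, the first value in this set that is a number and not a limit. Methoxy in place of hydrogen on an aromatic carbon, para to a large group, reads as an at least 1.4-fold lower number from compound 2 to compound 3 (0.17 log units; that floor lies within the scatter), so the true size of the change stays unknown and what can be read of it does not go beyond the usual scatter. The remaining values are limits of the assay and not numbers: the limit of > 10000 nM in this assay, at which 2 of the 3 values shown sit.

The compounds shown leave open whether another group in the same place, such as a hydroxyl, an amine or a carboxylic acid, would give a lower number than methoxy does. They also leave open whether a longer chain, such as ethoxy, would keep the number that methoxy gives.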